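Predicting compound 4 when every measured value is a limit

This account rests on a few compounds, and the source may have more. Where it says the series, first, only, none or still open, it means among the compounds named here.

The values so far in a functional assay on MDA-MB-231 cells (Homo sapiens) for antiproliferative activity, read by MTT assay, with a stated time of 24 h (on this read-out higher numbers stand for weaker inhibition and lower numbers for stronger inhibition), are these:
Compound 1 `Cc1ccccc1NNC(=O)c1cccc(NS(=O)(=O)c2cnc(O)nc2O)c1` gives > 20000 nM as a limit
Compound 2 `O=C(NNc1ccc(F)cc1)c1cccc(NS(=O)(=O)c2cnc(O)nc2O)c1` gives > 20000 nM as a limit
Compound 3 `O=C(NNc1ccccc1F)c1ccccc1NS(=O)(=O)c1cnc(O)nc1O` gives > 20000 nM as a limit

Compound 2 stands only at a limit of the assay, so it has no true number to start from. The same holds for the other two measured compounds, and the whole record comes down to the limit of > 20000 nM in this assay, at which 3 of the 3 values shown sit, with nothing yet measured as a real value.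

The unmeasured compound 4 `O=C(NNC(=O)c1ccccc1Cl)c1cccc(NS(=O)(=O)c2cnc(O)nc2O)c1` differs from compound 2 in one place, on an amine nitrogen whose other neighbour is an amide-type nitrogen. The change is (2-chlorophenyl)carbonyl in place of 4-fluorophenyl on an amine nitrogen and in words it puts (2-chlorophenyl)carbonyl in place of 4-fluorophenyl.

Going by the values given here, the only measured step that bears on this one is a step that the two limits leave unreadable from compound 1 to compound 2 and it also changes the group on an amine nitrogen, but it gives no size to carry over. With no readable step to lean on, no shift in either direction can be argued, so in this assay no step beyond the usual scatter is expected. For compound 4 the expected change is a step that the limit leaves unreadable from compound 2 to compound 4 as a working figure only. Compound 4 is estimated at 25000 nM with a range from 8000 nM to 50000 nM and the assay is expected most likely to report only a limit again.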

Compound 4, half-maximal inhibitory concentration: 2360 nM
Compound 4: the middle estimate sits 11-fold (1.03 log units) above what was measured; measured number below the stated range.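

In this assay, (2-chlorophenyl)carbonyl in place of 4-fluorophenyl, on an amine nitrogen whose other neighbour is an amide-type nitrogen, gives an at least 8.4-fold lower number from compound 2 to compound 4 (0.92 log units; beyond the scatter). The same group in place of 2-methylphenyl gives an at least 8.4-fold lower number from compound 1 to compound 4 (0.92 log units; beyond the scatter), so this position, whose earlier steps between limits cannot be read, does respond to a change of group, and both steps are minimum sizes that leave the full size unknown. Compound 4 is the only compound shown with a real number and the only one with a carbonyl on this nitrogen, while the others stay at the limit: the limit of > 20000 nM in this assay, at which 3 of the 4 values shown sit.

The compounds shown do not separate the part played by the carbonyl from that of the chlorine, since the two enter together; a plain benzoyl group, an acetyl group or a (2-methylphenyl)carbonyl group at the same place would begin to pull them apart. On these data alone, it also remains open whether the gain carries over to the arrangement of the core seen in compound 3, and whether a different acyl group, such as a pyridinecarbonyl, would lower the number further.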